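A few compounds are considered here, and "the series" means these few. Any claim that something is new, unique, unknown or untested is made for them only; others in the source may bear on it.

Measured so far in a functional assay on the whole organism (plasma, strain albino) for inhibition, with Rattus norvegicus as the target, with stated times of 1 h and 4 h, at a dose of 25 mg/kg by the oral route; on this read-out higher numbers stand for a stronger effect at the one dose given and lower numbers for a weaker effect:
compound 1 `COc1ccc(Cl)cc1C(=O)Nc1ccc(C2=NN(c3ccccc3)C(c3ccccc3[N+](=O)[O-])C2)cc1` gives 73.3%
compound 2 `COc1ccc(Cl)cc1C(=O)Nc1ccc(C2=NN(c3ccccc3)C(c3ccc([N+](=O)[O-])cc3)C2)cc1` gives 75.3%
compound 3 `COc1ccc(Cl)cc1C(=O)Nc1ccc(C2=NNC(c3ccccc3[N+](=O)[O-])C2)cc1` gives 72.3%

Two single changes connect these. From compound 1 to compound 2 the change is 4-nitrophenyl in place of 2-nitrophenyl on a saturated ring carbon and the step is a number 2 percentage points higher from compound 1 to compound 2 (within the scatter). Compound 3 gives a value within the scatter of the other two, and against compound 1 the step is a number 1 percentage points lower from compound 1 to compound 3 (within the scatter).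

Compound 4 `COc1ccc(Cl)cc1C(=O)Nc1ccc(C2=NNC(c3ccc([N+](=O)[O-])cc3)C2)cc1` is not yet measured. It differs from compound 3 by 4-nitrophenyl in place of 2-nitrophenyl on a saturated ring carbon, the same kind of change as from compound 1 to compound 2; the two cores differ by hydrogen in place of phenyl on an amine nitrogen in a ring. Around the place, the earlier change is next to the ring atom that bears a phenyl group (6 heavy atoms), which the present one is not.

In this assay the step is expected to be a number 1.7 percentage points higher from compound 3 to compound 4 (within the scatter), beside the earlier a number 2 percentage points higher from compound 1 to compound 2 (within the scatter), resting only on that one step, which lay within the scatter. Compound 4 is estimated at 74%, expected between 64% and 84%.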

Compound 4, a percentage reported as inhibition, in the whole organism at one dose (the size of the read-out at that dose, not a potency): 76.3%
Compound 4: the middle estimate sits 2.3 percentage points below what was measured; the measured number falls inside the stated range.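

In this assay, 4-nitrophenyl in place of 2-nitrophenyl gives a number 4 percentage points higher from compound 3 to compound 4 (within the scatter), and the change reads the same on both cores: the same change on two cores in this assay, a number 2 percentage points higher (within the scatter) from compound 1 to compound 2 and a number 4 percentage points higher (within the scatter) from compound 3 to compound 4, 2 percentage points apart, within the scatter of two such steps

Hydrogen in place of phenyl on the ring nitrogen gives a number 1 percentage points higher from compound 2 to compound 4 (within the scatter), and this change also reads the same on both cores: the same change on two cores in this assay, a number 1 percentage points lower (within the scatter) from compound 1 to compound 3 and a number 1 percentage points higher (within the scatter) from compound 2 to compound 4, 2 percentage points apart, within the scatter of two such steps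

Going by these compounds alone, all of these steps lie within the scatter, so the agreement shows only that neither change has a visible effect at this one dose on these cores, not that a step of real size would carry from one core to another.

Still open, on these data alone, is whether an amine or a carboxylic acid in place of the nitro group, or a longer chain in place of hydrogen or phenyl on the ring nitrogen, would move the read-out beyond the scatter.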